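Adding a fluorine beside the nitrile of compound 3

A few compounds are considered here, and "the series" means these few. Any claim that something is new, unique, unknown or untested is made for them only; others in the source may bear on it.

Of the compounds shown here, three sharing one core have been measured. In an assay for inhibition of Indoleamine 2,3-dioxygenase 1 (Homo sapiens), read by fluorescence, with a stated time of 1 h (a lower number here means a stronger inhibitor, a higher number a weaker inhibitor), compound 1 `NS(=O)(=O)CC(=O)NCCSc1nonc1/C(=N/O)Nc1cccc(C(F)F)c1` gives 130 nM, compound 2 `NS(=O)(=O)CC(=O)NCCSc1nonc1/C(=N/O)Nc1cccc(Cl)c1` gives 21 nM, and compound 3 `N#Cc1cccc(N/C(=N\O)c2nonc2SCCNC(=O)CS(N)(=O)=O)c1` gives 240 nM. Compound 3 therefore has the highest number of the three: its value sits close to that of compound 1, since a 1.8-fold higher number from compound 1 to compound 3 (0.27 log units; within the scatter), while compound 2 stands well apart, as an 11-fold higher number from compound 2 to compound 3 (1.06 log units; beyond the scatter) shows.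

Compound 4 `N#Cc1cc(N/C(=N\O)c2nonc2SCCNC(=O)CS(N)(=O)=O)ccc1F` differs from compound 3 in a single place: fluoro in place of hydrogen on an aromatic carbon. Compound 3 already carries the cyano group; compound 4 keeps it and gains a fluoro next to it.

Going by the values given here, none of the measured steps tests this change. Among the compounds with values here, the steps of a 6.2-fold lower number from compound 1 to compound 2 (0.79 log units; beyond the scatter) and an 11-fold higher number from compound 2 to compound 3 (1.06 log units; beyond the scatter) exchange the group on the ring itself, and a 1.8-fold higher number from compound 1 to compound 3 (0.27 log units; within the scatter) does the same; no pair adds a second small group while keeping the first. Without a precedent, the expectation rests on the small size of the entering group, and a step within the usual scatter is expected, with a slight lean toward a lower number. Compound 4 is expected to give about 180 nM in this assay, within a range from 70 nM to 450 nM, which corresponds to an expected step of a 1.3-fold lower number from compound 3 to compound 4 (0.12 log units; within the scatter).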

Compound 4, half-maximal inhibitory concentration: 150 nM
Compound 4: the middle estimate sits 1.2-fold (0.08 log units) above what was measured; the measured number falls inside the stated range.
By their numbers in this assay, from the lowest: compound 2; then compounds 1, 4 and 3 (each within the scatter of the next).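

In this assay, a fluoro on the aromatic carbon ortho to the cyano group and para to a large group gives the first test of adding a second small group while keeping the first, and the result is a 1.6-fold lower number from compound 3 to compound 4 (0.20 log units; within the scatter); this position therefore accepts a fluorine with no change that can be told from the scatter. The 3-cyano-4-fluorophenyl group stays level with 3-(difluoromethyl)phenyl, as a 1.2-fold higher number from compound 1 to compound 4 (0.06 log units; within the scatter) shows, but still falls clearly short of 3-chlorophenyl, as a 7.1-fold higher number from compound 2 to compound 4 (0.85 log units; beyond the scatter) shows, so adding the fluoro does not bring the nitrile series up to compound 2. No measurement shown here offers an explanation for this result.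

The compounds shown leave open whether the same fluoro would also make so little difference on the 3-chlorophenyl ring of compound 2, where the number is much lower. They also leave open whether this position would accept something larger than a single atom, such as a methoxy group or an amine, or whether the small size of fluoro is what keeps the step within the scatter.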